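From Carbamoyl to Methyl Imidate on a Shared Core

The source may report more compounds than this note shows. Statements on the series, on what has been measured and on what is new or still open speak of the compounds shown alone.

The shared core of compound 2 `NC(=O)c1cn(COCCO)c2ncnc(N)c12` carries a carbamoyl group on a five-membered aromatic ring. In an ADME assay on BSC-1 cells (Cercopithecidae) for cytotoxicity (on this read-out lower numbers stand for stronger inhibition and higher numbers for weaker inhibition), compound 2 gives > 100000 nM, which is a limit of the assay rather than a measured number. Its only measured relative, compound 1 `N#Cc1cn(COCCO)c2ncnc(N)c12`, bears a cyano group where compound 2 bears the carbamoyl. In this assay compound 1 gives > 320000 nM, again a limit and not a number. The step that the two limits leave unreadable from compound 1 to compound 2 therefore cannot be read as a size, since the limit of > 100000 nM in this assay, at which 1 of the 2 values shown sits, and the limit of > 320000 nM in this assay, at which 1 of the 2 values shown sits, both sit at limits. Compound 3 `COC(=N)c1cn(COCCO)c2ncnc(N)c12` differs from compound 2 by a group of 4 heavy atoms (2 carbon, 1 nitrogen, 1 oxygen; no ring) in place of a group of 3 heavy atoms (1 carbon, 1 nitrogen, 1 oxygen; no ring), on an aromatic carbon. Going by the values given here, no measured step bears directly on this change; the single comparison, with both ends at limits, shows merely that neither the carbamoyl nor the cyano compound produced measurable cytotoxicity. Compound 3 is expected to behave alike, with an expected step of a number no higher from compound 2 to compound 3 (the limit leaves the size open) that stays within the scatter. The estimate for compound 3 is 100000 nM, ranging from 30000 nM to 320000 nM, and most probably it will again be reported only as a limit.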

Compound 3, half-maximal inhibitory concentration: > 100000 nM
Compound 3: only a limit was reported; the forecaster's own chance of this, stated with the estimate: 70%; the middle value lies on the limit itself.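

In this assay compound 3 gives > 100000 nM, which is a limit of the assay and not a number. Going by these compounds alone, compound 1, compound 2 and compound 3 all stand at limits, and no step among them can be read as a size. The compounds shown leave open whether any of them has a measurable value in this assay, and how the three would rank.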